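A Smaller Ether Group and an Expected Loss of Potency

This account rests on a few compounds, and the source may have more. Where it says the series, first, only, none or still open, it means among the compounds named here.

Compound 1 `COc1cc(COC(c2ccc(OC)c(OC)c2OC)c2cccc3ccccc23)cc(OC)c1`: in a functional assay on MCF7 cells (Homo sapiens) for inhibition, read by sulforhodamine B assay, with a stated time of 48 h (a lower number here means a stronger inhibitor, a higher number a weaker inhibitor), compound 1 reaches only the limit > 20000 nM.
Compound 2 `COc1ccc(C(OCc2ccccc2)c2cccc3ccccc23)c(OC)c1OC`: in this assay compound 2 gives 14100 nM.
Compound 3 `C=CCC(O)(c1ccc(OC)c(OC)c1OC)c1cccc2ccccc12`: in this assay compound 3 reaches only the limit > 20000 nM.

Going by the values given here, compound 2 thus holds the only real number among the three, the other two sitting at the limit of > 20000 nM in this assay, at which 2 of the 3 values shown sit. Compound 4 `C=CCOC(c1ccc(OC)c(OC)c1OC)c1cccc2ccccc12` differs from compound 2 by vinyl in place of phenyl on a saturated chain carbon bound to an oxygen on a saturated carbon. Among the compounds with values here, the one measured step, an at least 1.4-fold lower number from compound 1 to compound 2 (0.15 log units; that floor lies within the scatter), altered a group at the same place and stayed within the scatter, so it offers little guidance for swapping phenyl for vinyl. Compound 3, which also carries an allyl chain, reaches only the limit > 20000 nM. The step of a 1.8-fold higher number from compound 2 to compound 4 (0.25 log units; within the scatter) is therefore expected to weaken inhibition, quite possibly past the limit. For compound 4 the estimate is 25000 nM, in the range 10000 nM to 60000 nM.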

Compound 4, half-maximal inhibitory concentration: > 20000 nM
Compound 4: no number, only a limit (the forecaster's own chance of this, stated with the estimate: 60%); the middle value lies beyond the limit too.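

Putting vinyl in place of phenyl on a saturated chain carbon bound to an oxygen on a saturated carbon gives an at least 1.4-fold higher number from compound 2 to compound 4 (0.15 log units; that floor lies within the scatter), so the step can be read only as a floor. The step between compound 1 and compound 4 cannot be read. Compound 4 gives a limit and not a number, which leaves compound 2 with the only real number: the limit of > 20000 nM in this assay, at which 3 of the 4 values shown sit.

As far as these compounds go, how far compound 4 lies past its limit stays open. So does the effect of an amine, a carboxylic acid or a longer chain than allyl at this place.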